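This account rests on a few compounds, and the source may have more. Where it says the series, first, only, none or still open, it means among the compounds named here.

Measured so far in an assay on cells for displacement of a labelled ligand from melatonin receptor type 1A (Homo sapiens), using the Cheng-Prusoff equation, with a stated time of 90 min; a lower number here means a stronger inhibitor, a higher number a weaker inhibitor:
- compound 1, `CC(=O)NCCN(C)c1cccc(OCCCCN)c1`: 3090 nM
- compound 2, `CC(=O)NCCN(C)c1cccc(OCCCCCCNC(=O)Oc2cccc(-c3cccc(C(N)=O)c3)c2)c1`: 38.9 nM
- compound 3, `CC(=O)NCCN(C)c1cccc(OCCCCCCOc2cccc(O)c2)c1`: 58.9 nM

All three share the same core, an acetamidoethyl-methylamino-phenyl unit bearing an alkoxy chain, and differ only in the chain and what terminates it. Compound 1, whose chain ends in a free amino group, gives the highest inhibition constant of the three in this assay; compound 3, with a 3-hydroxyphenoxy terminus on a longer chain, and compound 2, with a carbamate-linked biaryl carboxamide, both sit far lower, well beyond the scatter, as their values show.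

Compound 4, `CC(=O)NCCN(C)c1cccc(OCCCCOc2cccc(O)c2)c1`, has not yet been measured. It differs from compound 1 by 3-hydroxyphenoxy in place of amino on a saturated chain carbon, four bonds along the chain from an oxygen on an aromatic ring. The change therefore installs on the chain of compound 1 the same terminal group that compound 3 carries on its longer chain. Among the measured compounds shown here, no measured pair isolates this exact change; what the numbers show is that the amine terminus of compound 1 is the weakest point of the set, and that the two chain-extended aromatic termini of compound 2 and compound 3 give much lower values.

On that basis a large step toward a lower number is expected, a 28-fold lower number from compound 1 to compound 4 (1.45 log units; beyond the scatter), though the shorter chain of compound 4 relative to compound 3 leaves the size uncertain. Compound 4 is estimated at 110 nM, with a likely range of 25 nM to 450 nM.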

Compound 4, inhibition constant: 186 nM
Estimate against measurement, compound 4: 1.7-fold (0.23 log units) below, and the stated range covers the measured number.
By their numbers in this assay, from the lowest: compounds 2 and 3 (each within the scatter of the next); then compound 4; then compound 1.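

In this assay, among the compounds shown here, 3-hydroxyphenoxy in place of amino on a saturated chain carbon, four bonds along the chain from an oxygen on an aromatic ring, gives a 17-fold lower number from compound 1 to compound 4 (1.22 log units; beyond the scatter) as the first step that changes one place only. The earlier compounds shown here differed from compound 1 in both chain and terminus, whereas here the chain stays the same, so this large step belongs to the exchange of the terminal group alone. No evidence is available on what lies behind the size of this step.

With the same terminus on a longer chain, compound 3 gives 58.9 nM and compound 4 gives 186 nM, but chain length is not isolated from other changes by any listed step, so its contribution remains open. The compounds shown also leave open whether the hydroxyl on the terminal ring is needed, which an unsubstituted phenoxy terminus would address, and how a terminal carboxylic acid or a tertiary amine on this chain would compare with amino and 3-hydroxyphenoxy.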